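The source may report more compounds than this note shows. Statements on the series, on what has been measured and on what is new or still open speak of the compounds shown alone.

In a functional assay on K562 cells (Homo sapiens), read by MTT assay, with a stated time of 72 h (on this read-out higher numbers stand for weaker inhibition and lower numbers for stronger inhibition), compound 3 `CN(C)c1ncnc2c1c(-c1ccoc1)cn2[C@@H]1O[C@H](CO)[C@@H](O)[C@H]1O`, which carries a furan-3-yl group, gives 1540 nM. Within the data shown here, this is the higher of the two numbers measured so far, since compound 1 `CSc1ncnc2c1c(-c1ccsc1)cn2[C@@H]1O[C@H](CO)[C@@H](O)[C@H]1O` gives 450 nM, and that gap lies beyond the scatter. Compound 2 `CNc1ncnc2c1c(-c1ccsc1)cn2[C@@H]1O[C@H](CO)[C@@H](O)[C@H]1O` yields only a limit of the assay, > 20000 nM.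

Compound 4 `CN(C)c1ncnc2c1c(-c1ccsc1)cn2[C@@H]1O[C@H](CO)[C@@H](O)[C@H]1O` differs from compound 3 in one place: thiophen-3-yl in place of furan-3-yl on an aromatic carbon. Thiophen-3-yl thus stands in place of furan-3-yl on an aromatic carbon of the five-membered aromatic ring with 1 nitrogen, and the rest of the structure is unchanged. Among the measured compounds shown here, no measured pair makes this exchange. For the measured compounds named here, the one measured step, an at least 44-fold higher number from compound 1 to compound 2 (1.64 log units; beyond the scatter), puts methylamino in place of methylsulfanyl on an aromatic carbon. It is large, but it concerns a different group, so it gives no size for the furan-3-yl to thiophen-3-yl exchange and only warns that compounds carrying thiophen-3-yl can differ widely in this assay. No step beyond the scatter is therefore expected, and the estimated change is a 1.3-fold higher number from compound 3 to compound 4 (0.11 log units; within the scatter), with real uncertainty in both directions. For compound 4 the expected value in this assay is 2000 nM, within an estimated range of 500 nM to 10000 nM.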

Compound 4, half-maximal inhibitory concentration: 530 nM
The estimate for compound 4 lay 3.8-fold (0.58 log units) above the measured number; the range from low to high includes it.
By their numbers in this assay, from the lowest: compounds 1 and 4 (each within the scatter of the next); then compound 3. At a limit, above all of these: compound 2.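

In this assay, the compounds shown now include a measured pair for the exchange on this aromatic carbon of the five-membered aromatic ring with 1 nitrogen, and thiophen-3-yl in place of furan-3-yl, two rings of the same size, gives a step beyond the scatter: a 2.9-fold lower number from compound 3 to compound 4 (0.46 log units; beyond the scatter). With thiophen-3-yl held fixed, the other place on the core also becomes clearer, since dimethylamino and methylsulfanyl cannot be told apart (a 1.2-fold higher number from compound 1 to compound 4 (0.07 log units; within the scatter)), while the second methyl on the nitrogen makes a large difference (an at least 37-fold lower number from compound 2 to compound 4 (1.57 log units; beyond the scatter)). The value of compound 2 behind that last step is a limit and not a number: the limit of > 20000 nM in this assay, at which 1 of the 4 values shown sits.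

On these data alone, only compound 3 and compound 4 compare the two rings, and both carry dimethylamino, so it remains open whether the same exchange would give a step of similar size with methylsulfanyl or methylamino on the core. The compounds shown also leave open how a phenyl ring or a propyl chain would read on this aromatic carbon, and how an unsubstituted amine would read in place of dimethylamino.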